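An isomeric ring swap at the chain carbon

The source may report more compounds than this note shows. Statements on the series, on what has been measured and on what is new or still open speak of the compounds shown alone.

In an in vitro ADME assay on microsomes from liver (Rattus norvegicus) for metabolic stability (a lower number here means slower removal, a higher number faster removal of the compound), compound 1 `Cc1cccc(Cn2c(=O)[nH]c3c(N)nc(C(F)(F)F)cc32)n1` gives 27 mL.min-1.g-1. Compound 2 `Cc1cc(Cn2c(=O)[nH]c3c(N)nc(C(F)(F)F)cc32)no1` gives < 9 mL.min-1.g-1, which is a limit of the assay and not a number. Going by the values given here, the one measured step, an at least 3.0-fold lower number from compound 1 to compound 2 (0.47 log units; beyond the scatter), placed 5-methyl-1,2-oxazol-3-yl where 6-methylpyridin-2-yl had stood and lies beyond the scatter. Compound 3 `Cc1nc(Cn2c(=O)[nH]c3c(N)nc(C(F)(F)F)cc32)co1` has 2-methyl-1,3-oxazol-4-yl in place of 5-methyl-1,2-oxazol-3-yl on a saturated chain carbon bound to an aromatic nitrogen. The two have the same atoms, joined differently. Among the compounds with values here, no measured step exchanges one of these two groups for the other, so the step of compound 1 bears only indirectly. No step beyond the scatter is expected in this assay, and any movement is expected to be upward. The expected step of an at least 1.1-fold higher number from compound 2 to compound 3 (0.04 log units; that floor lies within the scatter) is small. For compound 3 the estimated value is 10 mL.min-1.g-1, with an expected range of 5 mL.min-1.g-1 to 22 mL.min-1.g-1.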

Compound 3, intrinsic clearance in microsomes: < 10 mL.min-1.g-1
Compound 3: no number, only a limit (the forecaster's own chance of this, stated with the estimate: 45%); the middle value sits exactly at the limit.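

With 2-methyl-1,3-oxazol-4-yl on the saturated chain carbon bound to an aromatic nitrogen, replacing 6-methylpyridin-2-yl gives an at least 2.7-fold lower number from compound 1 to compound 3 (0.43 log units; beyond the scatter) in this assay, so the lower number is no longer tied to 5-methyl-1,2-oxazol-3-yl alone. The value of compound 3 is a limit of the assay and not a number: the limit of < 10 mL.min-1.g-1 in this assay, at which 1 of the 3 values shown sits. The step between compound 2 and compound 3 cannot be read, as both values are limits, and the two groups of the same atoms stay unordered in this assay.

As far as these compounds go, how far the true values of compound 2 and compound 3 lie past their limits remains open. Also open, from the compounds shown here alone, is whether a 1,3-oxazol-4-yl without its methyl, or with a carboxylic acid in place of that methyl, would keep the number as low.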